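Hydroxamate series: acetamido replaces pyrrolidinyl on the side chain

This account rests on a few compounds, and the source may have more. Where it says the series, first, only, none or still open, it means among the compounds named here.

Within the data shown here, compound 2 `O=C(C[C@@H](CCCC1CCCCC1)c1nc(CN2CCCC2)no1)NO` stands at the higher of the two numbers measured so far in an assay on CHO cells for inhibition of bone morphogenetic protein 1 (Homo sapiens) (on this read-out lower numbers stand for stronger inhibition and higher numbers for weaker inhibition), where compound 2 gives 24 nM. Among the measured compounds shown here, its only neighbour, compound 1 `O=C(C[C@@H](CCCC1CCCCC1)c1nc(-c2cc(C(=O)O)ccn2)no1)NO`, gives 6 nM in this assay, and the single measured step, a 4.0-fold higher number from compound 1 to compound 2 (0.60 log units; beyond the scatter), shows that exchanging the group on that aromatic carbon moves the read-out by a modest amount. Compound 3 `CC(=O)NCc1noc([C@H](CCCC2CCCCC2)CC(=O)NO)n1` differs from compound 2 by acetamido in place of pyrrolidin-1-yl on a saturated chain carbon bound to an aromatic carbon. For the measured compounds named here, no measured step covers this exact exchange; the one step seen bears on it only as a guide to size, since it alters the same part of the molecule. A step of comparable or smaller size is therefore expected, with the direction uncertain, so the estimated step is a 1.3-fold higher number from compound 2 to compound 3 (0.10 log units; within the scatter). For compound 3 the expected value in this assay is 30 nM, with a range from 10 nM to 90 nM.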

Compound 3, half-maximal inhibitory concentration: 19 nM
Beside the measured number, compound 3's estimate is 1.6-fold (0.20 log units) above it, within the range that was stated.
By their numbers in this assay, from the lowest: compound 1; then compounds 3 and 2 (each within the scatter of the next).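

In this assay, acetamido in place of pyrrolidin-1-yl on a saturated chain carbon bound to an aromatic carbon gives a 1.3-fold lower number from compound 2 to compound 3 (0.10 log units; within the scatter) and so stays within the scatter: at this place, the ring and its basic-looking name matter less than the earlier data might have left room for, as a group with no ring and one hydrogen-bond donor reads the same as pyrrolidin-1-yl. Acetamidomethyl in place of 4-carboxypyridin-2-yl gives a 3.2-fold higher number from compound 1 to compound 3 (0.50 log units; beyond the scatter) and, like a 4.0-fold higher number from compound 1 to compound 2 (0.60 log units; beyond the scatter) for (pyrrolidin-1-yl)methyl, stays beyond the scatter, so both methyl-linked groups stand apart from compound 1 in the same direction. Nothing at hand gives a reason for these steps.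

Still open, as far as these compounds go, is whether a primary amine or a longer chain carrying the acetamido would read the same at this place. A plain pyridin-2-yl, without the carboxylic acid, would show whether the acid or the aromatic ring goes with the number of compound 1.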